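Ethoxycarbonyl in place of cyano on the shared core

This account rests on a few compounds, and the source may have more. Where it says the series, first, only, none or still open, it means among the compounds named here.

For the measured compounds named here, in a functional assay on HT-29 cells (Homo sapiens) for inhibition, read by MTT assay (a lower number here means a stronger inhibitor, a higher number a weaker inhibitor), compound 3 (`N#Cc1c(N)sc(C(=O)Nc2ccccc2)c1-c1ccccc1`) gives 8390 nM, the highest number of the three measured so far and therefore the weakest inhibitor of the set. Compound 1 (`N#Cc1c(N)sc(C(=O)Nc2ccc(Cl)cc2)c1-c1ccccc1`) stands at 650 nM and compound 2 (`CCOC(=O)c1c(NC(=O)CC#N)sc(C(=O)Nc2ccc(Cl)cc2)c1-c1ccccc1`) at 620 nM, and these two values lie within the usual scatter of each other.

Compound 4 (`CCOC(=O)c1c(N)sc(C(=O)Nc2ccccc2)c1-c1ccccc1`) carries ethoxycarbonyl in place of cyano on an aromatic carbon of compound 3: ethoxycarbonyl in place of cyano on an aromatic carbon.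

Going by the values given here, the only measured step is a 13-fold higher number from compound 1 to compound 3 (1.11 log units; beyond the scatter), a large one, but it concerns hydrogen in place of chloro on an aromatic carbon, which is a different place and a different change. Among the compounds with values here, no measured step isolates the exchange of cyano for ethoxycarbonyl. Compound 2 also carries ethoxycarbonyl, but it differs from compound 1 in more than that one place. The closeness of compound 2 at 620 nM to compound 1 at 650 nM is therefore only a weak hint that this exchange need not move the number. No step beyond the scatter is expected in this assay, in either direction.

The expected change is a 1.2-fold lower number from compound 3 to compound 4 (0.08 log units; within the scatter). For compound 4 the estimated value is 7000 nM, with an expected range of 2500 nM to 20000 nM.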

Compound 4, half-maximal inhibitory concentration: 7490 nM
Compound 4: middle estimate off by 1.1-fold (0.03 log units), on the low side; the measured number falls inside the stated range.
By their numbers in this assay, from the lowest: compounds 2 and 1 (each within the scatter of the next); then compounds 4 and 3 (each within the scatter of the next).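

In this assay, the exchange of cyano for ethoxycarbonyl on this aromatic carbon of the shared core now has a measured step of its own, a 1.1-fold lower number from compound 3 to compound 4 (0.05 log units; within the scatter), which lies within the scatter. For the compounds shown here, earlier, the only pointer to this exchange came from a pair of compounds differing in more than one place; this single-place pair shows directly that, with hydrogen on the aromatic carbon where compound 1 carries chloro, the larger ethoxycarbonyl group leaves the number unmoved beyond the scatter. No measurement at hand bears on why the two groups read alike here.

As far as these compounds go, the chloro step, a 13-fold higher number from compound 1 to compound 3 (1.11 log units; beyond the scatter), has been read only with cyano on the shared core, so it remains open whether chloro in place of hydrogen gives a step of similar size with ethoxycarbonyl at this carbon. Also open, from the compounds shown here alone, is how far this position tolerates other groups, such as a carboxylic acid or a longer chain like butoxycarbonyl, since cyano and ethoxycarbonyl are the only two compared here in a single-place step.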